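This account rests on a few compounds, and the source may have more. Where it says the series, first, only, none or still open, it means among the compounds named here.

Measured in a physicochemical assay for solubility, in phosphate buffer, with a stated time of 24 h, at pH 7.4; a lower number here means a less soluble compound, a higher number a more soluble compound:
- compound 1 `COc1ccc(-c2ccc(OCc3cc(C(=O)NS(=O)(=O)c4ccccc4)oc3C)cc2)c(C)c1` gives 20 ug/mL
- compound 2 `CCCS(=O)(=O)NC(=O)c1cc(COc2ccc(-c3ccc(OC)cc3)cc2)c(C)o1` gives 7 ug/mL
- compound 3 `COc1ccc(-c2ccc(OCc3cc(C(=O)NS(=O)(=O)c4c(C)noc4C)oc3C)cc2)c(C)c1` gives 200 ug/mL

Compound 1, at 20 ug/mL, is second highest of the three numbers, above compound 2 and below compound 3. Compound 4 `Cc1oc(C(=O)NS(=O)(=O)c2ccccc2)cc1COc1ccc(-c2ccc(OC(F)F)cc2)cc1` differs from compound 1 as follows: 4-(difluoromethoxy)phenyl in place of 4-methoxy-2-methylphenyl on an aromatic carbon. In words, 4-(difluoromethoxy)phenyl stands in place of 4-methoxy-2-methylphenyl on an aromatic carbon, para to a large group. Among the measured compounds shown here, the only measured step, a 10-fold higher number from compound 1 to compound 3 (1.00 log units; beyond the scatter), replaces phenyl on a sulfonyl sulfur, and compound 4 keeps that phenyl. For the measured compounds named here, no measured step changes the group exchanged here, so no shift beyond the scatter is expected in this assay. The expected step is a 1.3-fold lower number from compound 1 to compound 4 (0.12 log units; within the scatter). For compound 4 the estimated value is 15 ug/mL, with an expected range from 4 ug/mL to 55 ug/mL.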

Compound 4, solubility: < 0.6 ug/mL
Compound 4: a limit, no number; the forecaster's own chance of this, stated with the estimate: 5%; middle value at least 25-fold (1.39 log units) from the limit.
By their numbers in this assay, from the lowest: compound 2; then compound 1; then compound 3. At a limit, below all of these: compound 4.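

Among the compounds shown here, until now, the only step in this assay came from a change on the sulfonyl sulfur, but this position also counts: with the phenyl on that sulfur unchanged, 4-(difluoromethoxy)phenyl in place of 4-methoxy-2-methylphenyl gives an at least 33-fold lower number from compound 1 to compound 4 (1.52 log units; beyond the scatter). Compound 4 gives a limit of the assay, not a number: the limit of < 0.6 ug/mL in this assay, at which 1 of the 4 values shown sits.

The exchange alters both the methyl group and the methoxy group at once, so the compounds shown do not tell which alteration carries the step. They also leave open how an amine at this position would read in this assay.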